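Swapping Propoxy for Cyano on a Tolerated Scaffold

The source may report more compounds than this note shows. Statements on the series, on what has been measured and on what is new or still open speak of the compounds shown alone.

Compound 1 `COCOc1ccc(CN(Cc2ccc(C(C)(C)C)cc2)Cc2cc3cc(C)ccc3[nH]c2=O)cc1` and compound 2 `CCCOc1ccc(CN(Cc2ccc(C(C)(C)C)cc2)Cc2cc3cc(C)ccc3[nH]c2=O)cc1` share one core and differ only in the chain on the aromatic oxygen. In a toxicity assay on MDCK cells (Canis lupus familiaris) for cytotoxicity, read by crystal violet staining, with a stated time of 48 h (a lower number here means that less compound is tolerated, a higher number that more compound is tolerated), compound 1 gives 6400 nM. Compound 2 in this assay is reported only as a limit, > 5000 nM, not as a number. Compound 2 thus sits at the limit of > 5000 nM in this assay, at which 1 of the 2 values shown sits. The step that the limit leaves unreadable from compound 1 to compound 2 can therefore not be sized, and it leaves no readable guide.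

Compound 3 `Cc1ccc2[nH]c(=O)c(CN(Cc3ccc(C#N)cc3)Cc3ccc(C(C)(C)C)cc3)cc2c1` makes a different exchange: cyano in place of propoxy on an aromatic carbon. Among the measured compounds shown here, no measured step in this assay covers this exchange, so the expectation rests only on where the measured compounds fall. Because compound 1 gives 6400 nM, and compound 2 is tolerated at least as far, the change is expected to leave tolerance in the same region. The step that the limit leaves unreadable from compound 2 to compound 3 is expected to stay within the usual scatter. Compound 3 is estimated at 7000 nM, with a range from 3000 nM to 20000 nM.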

Compound 3, half-maximal cytotoxic concentration: > 5000 nM
Compound 3 gave a limit, no number; the forecaster's own chance of this, stated with the estimate: 50%; the middle value lies beyond the limit too.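

In this assay, no step among compound 1, compound 2 and compound 3 can be read, because compound 2 and compound 3 are reported only as a limit, not as a number: the limit of > 5000 nM in this assay, at which 2 of the 3 values shown sit.

This leaves open how much of compound 2 or compound 3 is tolerated, and whether exchanging propoxy for cyano changes that tolerance at all.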